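Chloro for methyl on the core of compound 1

A few compounds are considered here, and "the series" means these few. Any claim that something is new, unique, unknown or untested is made for them only; others in the source may bear on it.

Measured compounds:
compound 1 `Cc1nc(N[C@@H]2C[C@H]3CC[C@@H]2C3)c2cc(-c3ccc(Cl)cc3)ccc2n1`, 444 nM
compound 2 `Cc1nc(N[C@@H]2C[C@H]3CC[C@@H]2C3)c2cc(-c3ccccc3Cl)ccc2n1`, 496 nM
compound 3 `Cc1nc(N[C@@H]2C[C@H]3CC[C@@H]2C3)c2cc(-c3ccc(Cl)c(Cl)c3)ccc2n1`, 419 nM

All three were read in a functional assay for positive allosteric modulation of GABA-B receptor (Homo sapiens), read by GTPgammaS binding; on this read-out higher numbers stand for an effect only at larger amounts of compound and lower numbers for an effect already at smaller amounts. Compound 1 sits second highest of the three numbers; its nearest neighbour is compound 3 (a 1.1-fold lower number from compound 1 to compound 3 (0.03 log units; within the scatter)), its furthest is compound 2 (a 1.1-fold higher number from compound 1 to compound 2 (0.05 log units; within the scatter)), and the remaining pair is likewise flat (a 1.2-fold lower number from compound 2 to compound 3 (0.07 log units; within the scatter)). Every step measured so far stays within the scatter.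

Compound 4 `Clc1ccc(-c2ccc3nc(Cl)nc(N[C@@H]4C[C@H]5CC[C@@H]4C5)c3c2)cc1` differs from compound 1 by chloro in place of methyl on an aromatic carbon. Among the measured compounds shown here, none of the measured steps touches this site: they all move the chloro substituents of the pendant phenyl, and none of them moves the number beyond the scatter. Nothing in the measured set therefore argues for a shift in this assay in either direction, and the expectation is a step of no more than the scatter, a 1.0-fold higher number from compound 1 to compound 4 (0.01 log units; within the scatter). Compound 4 is accordingly estimated at 450 nM, with a range from 150 nM to 1400 nM in this assay.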

Compound 4, half-maximal effective concentration: 208 nM
For compound 4 the middle estimate is 2.2-fold (0.34 log units) above the measured one; the range from low to high includes it.
By their numbers in this assay, from the lowest: compounds 4, 3, 1 and 2 (each within the scatter of the next, the first and the last beyond it).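

In this assay the ring carbon between two ring nitrogen atoms of the shared core proves sensitive to a single exchange: a 2.1-fold lower number from compound 1 to compound 4 (0.33 log units; beyond the scatter) is a modest step beyond the scatter, while the steps among the chlorinated pendant phenyl groups of compounds 1, 2 and 3 all stay within it. Methyl and chloro match in the computed counts of heavy atoms and hydrogen-bond donors and acceptors, so those counts do not separate compound 1 from compound 4. The finding rests on this one pair, and no measurement here accounts for the step.

Going by these compounds, whether the exchange carries over to the pendant groups of compound 2 and compound 3 remains open. Also open, on these data alone, is how this carbon responds to hydrogen, an amine or a methoxy group, in size or direction.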